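Cyclohexyl in place of hexyl: an expected shift

The source may report more compounds than this note shows. Statements on the series, on what has been measured and on what is new or still open speak of the compounds shown alone.

Measured so far in a physicochemical assay for solubility, at pH 7.4 (on this read-out higher numbers stand for higher solubility and lower numbers for lower solubility), are three compounds:
- Compound 1 `CCCCCCc1nc(-c2ccc(CNC(=O)[C@H]3NCC[C@@H]3O)cc2)no1` gives > 50 ug/mL as a limit.
- Compound 2 `O=C(NCc1ccc(-c2noc(CCC3CC3)n2)cc1)[C@H]1NCC[C@@H]1O` gives > 50 ug/mL as a limit.
- Compound 3 `CCCCCCCCc1nc(-c2ccc(CNC(=O)[C@H]3NCC[C@@H]3O)cc2)no1` gives 4 ug/mL as a number.

Among the compounds with values here, compound 3 thus holds the only true number in the set. Compound 4 `O=C(NCc1ccc(-c2noc(CCC3CCCCC3)n2)cc1)[C@H]1NCC[C@@H]1O` carries cyclohexyl in place of hexyl on a saturated chain carbon, two bonds along the chain from an aromatic carbon. Within the data shown here, two measured steps bear on this: an at least 12-fold lower number from compound 2 to compound 3 (1.09 log units; beyond the scatter) at that same place, and also an at least 12-fold lower number from compound 1 to compound 3 (1.09 log units; beyond the scatter) on the same chain. Both are large and both rest on a limit. Compound 4 again has a ring at that place, so the expectation in this assay is a partial upward reversal of an at least 12-fold lower number from compound 2 to compound 3 (1.09 log units; beyond the scatter) and no more. The expected size is a 3.0-fold higher number from compound 3 to compound 4 (0.48 log units; beyond the scatter) as estimated here. The estimated value for compound 4 is 12 ug/mL within 3 ug/mL to 45 ug/mL as its range.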

Compound 4, solubility: 26 ug/mL
Compound 4: middle estimate off by 2.2-fold (0.34 log units), on the low side; measured number inside the range.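

In this assay, the change at this place, on a saturated chain carbon, two bonds along the chain from an aromatic carbon, gives a 6.5-fold higher number from compound 3 to compound 4 (0.81 log units; beyond the scatter), a step between two true numbers for groups with the same carbon count, only one of them holding a ring. Further steps read an at least 1.9-fold lower number from compound 2 to compound 4 (0.28 log units; that floor lies within the scatter) and an at least 1.9-fold lower number from compound 1 to compound 4 (0.28 log units; that floor lies within the scatter). Compound 1 and compound 2 each hold a limit and not a number: the limit of > 50 ug/mL in this assay, at which 2 of the 4 values shown sit.

As far as these compounds go, how far compound 4 truly lies from either of them stays open. So does whether a cyclopentyl group or an amine on the cyclohexyl ring would shift the number at this place.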